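Three half-lives at the limit and a fourth to come

The source may report more compounds than this note shows. Statements on the series, on what has been measured and on what is new or still open speak of the compounds shown alone.

Compound 1 `O=C(NCC1CCCCC1)N1C(=O)c2ccccc2S1(=O)=O` carries a cyclohexyl group. In a physicochemical assay for pharmacokinetics (a higher number here means that the compound lasts longer, a lower number that the compound disappears faster), compound 1 gives > 166 h, which is a limit of the assay rather than a number. Compound 2 `O=C(NCc1cccc2ccccc12)N1C(=O)c2ccccc2S1(=O)=O` also reaches only a limit, > 166 h. Compound 3 `CC(NC(=O)N1C(=O)c2ccccc2S1(=O)=O)c1ccccc1` likewise sits at a limit, > 166 h. Compound 1 thus stands where every measured value stands, because of the limit of > 166 h in this assay, at which 3 of the 3 values shown sit. Compound 4 `COc1cccc(CNC(=O)N2C(=O)c3ccccc3S2(=O)=O)c1` is not yet measured; it differs from compound 1 by 3-methoxyphenyl in place of cyclohexyl on a saturated chain carbon bound to an amide-type nitrogen. Among the measured compounds shown here, since no step between measured compounds can be seen, this change is expected to give no step beyond the scatter, an expected step of a number no higher from compound 1 to compound 4 (the limit leaves the size open). Compound 4 is therefore estimated at 166 h, within 80 h to 350 h, and most likely reported again only as a limit.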

Compound 4, half-life: > 166 h
Compound 4 was reported as a limit (the forecaster's own chance of this, stated with the estimate: 85%); the middle value lies on the limit itself.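

No step can be read between compound 1 and compound 4, because both values are limits: the limit of > 166 h in this assay, at which 4 of the 4 values shown sit. The compounds shown leave open how long any of them actually lasts in this assay, and whether 3-methoxyphenyl in place of cyclohexyl changes that.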